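A few compounds are considered here, and "the series" means these few. Any claim that something is new, unique, unknown or untested is made for them only; others in the source may bear on it.

Three compounds of the series share one core and differ only in the group on the carbonyl carbon. Compound 1 `COC(=O)c1sc(-c2ccc(Cl)cc2)nc1C(Br)Br` gives 222000 nM in an ADME assay on BHK15 cells (Mesocricetus auratus) for inhibition, read by XTT assay, with a stated time of 36 h; on this read-out higher numbers stand for weaker inhibition of growth and lower numbers for stronger inhibition of growth. Compound 2 `CNC(=O)c1sc(-c2ccc(Cl)cc2)nc1C(Br)Br` gives 74600 nM in this assay, and compound 3 `CN(C)/C=C/C(=O)c1sc(-c2ccc(Cl)cc2)nc1C(Br)Br` gives 38200 nM. Compound 2 stands second highest of the three: the step of a 3.0-fold lower number from compound 1 to compound 2 (0.47 log units; beyond the scatter) lies beyond the scatter, whereas the step of a 2.0-fold lower number from compound 2 to compound 3 (0.29 log units; within the scatter) does not, so compounds 2 and 3 cannot be ordered against each other. The step of a 5.8-fold lower number from compound 1 to compound 3 (0.76 log units; beyond the scatter) is the largest seen so far.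

Compound 4 `O=C(NC[C@@H](O)CO)c1sc(-c2ccc(Cl)cc2)nc1C(Br)Br` is not yet measured. Relative to compound 2 the change is 1,2-dihydroxyethyl in place of hydrogen on a saturated chain carbon bound to an amide-type nitrogen; cut one bond further out it reads methylamino to (2,3-dihydroxypropyl)amino. For the measured compounds named here, no measured step touches the substituent on the amide-type nitrogen; the measured steps all concern exchanges of the whole group on the carbonyl carbon, and the one step from compound 2 is within the scatter. No step beyond the scatter is therefore expected in this assay, in either direction. The expected change is a 1.1-fold lower number from compound 2 to compound 4 (0.06 log units; within the scatter). For compound 4 the estimate in this assay is 65000 nM, with a range from 22000 nM to 190000 nM.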

Compound 4, concentration for 50% growth inhibition: 158000 nM
For compound 4 the middle estimate is 2.4-fold (0.39 log units) below the measured one, and the stated range covers the measured number.
By their numbers in this assay, from the lowest: compounds 3 and 2 (each within the scatter of the next); then compounds 4 and 1 (each within the scatter of the next).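

In this assay the substituent on the amide-type nitrogen does register: 1,2-dihydroxyethyl in place of hydrogen on a saturated chain carbon bound to an amide-type nitrogen gives weaker inhibition of growth (a 2.1-fold higher number from compound 2 to compound 4 (0.33 log units; beyond the scatter)), a modest step. With this group the amide no longer stands apart from the methoxy compound (a 1.4-fold lower number from compound 1 to compound 4 (0.15 log units; within the scatter)), so compound 1 and compound 4 cannot be ordered, while the 2-(dimethylamino)ethenyl group on the carbonyl carbon remains separated from it (a 4.1-fold higher number from compound 3 to compound 4 (0.62 log units; beyond the scatter)). No measured evidence bears on the reason for this shift.

On these data alone, whether the shift follows the hydroxyl groups or the chain length stays open; a plain propyl or a 2-methoxyethyl group on the amide-type nitrogen would separate the two. As far as these compounds go, how a terminal amine or a carboxylic acid on that chain would read, and how the opposite stereoisomer would read, also stay open.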